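Furan-2-yl step on the ethyl thiourea side chain

The source may hold more compounds than are shown below. What is called first, only, known or untested is meant among the compounds shown, and "the series" means these compounds.

Measured so far in an ADME assay on MT4 cells (Homo sapiens) for cytotoxicity; a higher number here means that more compound is tolerated, a lower number that less compound is tolerated
Compound 1 `COc1cccc(NC(=S)Nc2cccc(C(F)(F)F)c2)c1` gives 26000 nM
Compound 2 `CCNC(=S)Nc1cccc(C(F)(F)F)c1` gives > 100000 nM as a limit
Compound 3 `CCOC(=O)c1ccc(NC(=S)Nc2cccc(C(F)(F)F)c2)cc1` gives 23000 nM

Compound 2 has only a limit and no number (the limit of > 100000 nM in this assay, at which 1 of the 3 values shown sits). Compound 4 `FC(F)(F)c1cccc(NC(=S)NCc2ccco2)c1` differs from compound 2 by furan-2-yl in place of methyl on a saturated chain carbon bound to an amide-type nitrogen. Going by the values given here, no measured pair differs in one place. Compound 1 at 26000 nM and compound 3 at 23000 nM carry an aromatic ring where compound 2 carries ethyl, and a move toward them is expected in this assay. The estimated size is an at least 2.2-fold lower number from compound 2 to compound 4 (0.34 log units; beyond the scatter), downward and only loosely fixed. Compound 4 is estimated at 45000 nM, with an expected range of 18000 nM to 100000 nM.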

Compound 4, half-maximal cytotoxic concentration: 43000 nM
Compound 4: middle estimate off by 1.0-fold (0.02 log units), on the high side; low and high end bracket the measured number.
By their numbers in this assay, from the lowest: compounds 3, 1 and 4 (each within the scatter of the next). At a limit, above all of these: compound 2.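

In this assay, furan-2-yl in place of methyl on a saturated chain carbon bound to an amide-type nitrogen gives an at least 2.3-fold lower number from compound 2 to compound 4 (0.36 log units; beyond the scatter). Going by these compounds alone, this change at this position therefore lowers the number measurably, and ethyl to (furan-2-yl)methyl is the first single-place change read. The size is only a floor, as the value of compound 2 is a limit: the limit of > 100000 nM in this assay, at which 1 of the 4 values shown sits.

Going by these compounds, whether the step needs the furan-2-yl ring or follows from any larger group here stays open. A longer chain such as propyl, a phenyl ring or an amine at this place would separate these readings.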